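A Chloropyridinyl Group in Place of a Carboxyethylcarbonyl Chain

A few compounds are considered here, and "the series" means these few. Any claim that something is new, unique, unknown or untested is made for them only; others in the source may bear on it.

Measured compounds:
compound 1, `COc1ccc(OC)c(Nc2cc(Nc3ccc(F)cc3)ncn2)c1`: 1720 nM
compound 2, `O=C(O)CCC(=O)Nc1cc(Nc2ccc(Cl)cc2)ncn1`: 3130 nM

Both compounds were tested in a functional assay on HCC827 cells (Homo sapiens) for antiproliferative activity, read by MTT assay, with a stated time of 72 h; on this read-out higher numbers stand for weaker inhibition and lower numbers for stronger inhibition. Compound 2 has the highest of the two numbers; its nearest neighbour is compound 1, whose number is lower, but the gap between them lies within the scatter of this assay, so no order between the two can be claimed. Compound 3, `Clc1ccc(Nc2cc(Nc3cccc(Cl)n3)ncn2)cc1`, has not yet been measured. It differs from compound 2 in one place: 6-chloropyridin-2-yl in place of (2-carboxyethyl)carbonyl on a nitrogen on an aromatic ring. Among the compounds with values here, no step between measured compounds is available to anchor the size of this change, so its effect can only be expected. Starting from compound 2, which gives 3130 nM in this assay, the step of a 2.1-fold lower number from compound 2 to compound 3 (0.32 log units; beyond the scatter) is expected to run toward a lower number and to be modest, possibly just beyond the scatter. Compound 3 is estimated at 1500 nM, within a range from 300 nM to 6000 nM.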

Compound 3, half-maximal inhibitory concentration: > 30000 nM
Compound 3: a limit, no number (the forecaster's own chance of this, stated with the estimate: 10%); middle value at least 20-fold (1.30 log units) from the limit.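

In this assay compound 3 gives only a limit of the assay, not a number: the limit of > 30000 nM in this assay, at which 1 of the 3 values shown sits. Placing 6-chloropyridin-2-yl in place of (2-carboxyethyl)carbonyl on this nitrogen gives an at least 9.5-fold higher number from compound 2 to compound 3 (0.98 log units; beyond the scatter), which is the first sign that the result in this assay depends on the group held at this position. Both groups carry 7 heavy atoms, so heavy-atom count alone does not set the outcome; the change swaps an open chain with a hydrogen-bond donor for an aromatic ring with none.

The compounds shown do not separate the loss of the carboxylic acid from the gain of the ring, or the ring from its chlorine. As far as these compounds go, how a pyridin-2-yl without chlorine or a plain acetyl group would read on this nitrogen remains open.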